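This account rests on a few compounds, and the source may have more. Where it says the series, first, only, none or still open, it means among the compounds named here.

Of the compounds shown here, three have so far been measured in an ADME assay on CHO-K1 cells (Cricetulus griseus) for activation, read by fluorescence, tested at 10 uM; a lower number here means a stronger effect, a higher number a weaker effect of the compound at the concentration tested. Compound 1 `COc1cc(/C=C/C(=O)/C=C(/C=C/c2ccc(O)c(OC)c2)NCCO)ccc1O` gives 90.9%, compound 2 `COCCNC(=C\C(=O)/C=C/c1ccc(O)cc1)/C=C/c1ccc(O)cc1` gives 75.1%, and compound 3 `COCCNC(=C\C(=O)/C=C/c1ccc(O)c(OC)c1)/C=C/c1ccc(O)c(OC)c1` gives 84.4%. Compound 3 and compound 1 differ in one place, (hydrogen in place of methyl on an oxygen on a saturated carbon), and this change gives a number 6.5 percentage points higher from compound 3 to compound 1 (within the scatter). The number for compound 2 lies within the scatter of that for compound 3, while the number for compound 1 is higher than that for compound 2, beyond the scatter. How the core of compound 2 differs from that of compound 3 is not broken down here. Compound 4 `O=C(/C=C(/C=C/c1ccc(O)cc1)NCCO)/C=C/c1ccc(O)cc1` has not yet been measured in this assay. It differs from compound 2 by hydrogen in place of methyl on an oxygen on a saturated carbon, the same change as from compound 3 to compound 1, at the same place. A step of a number 5.9 percentage points higher from compound 2 to compound 4 (within the scatter) is expected, because the same change gave a number 6.5 percentage points higher from compound 3 to compound 1 (within the scatter). Compound 4 is therefore estimated at 81%, expected to fall between 70% and 92%.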

Compound 4, a percentage reported as activity, at one concentration (the size of the read-out at that concentration, not a potency): 85.7%
Estimate against measurement, compound 4: 4.7 percentage points below; measured number inside the range.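

In this assay, exchanging 2-methoxyethyl for 2-hydroxyethyl gives a number 10.6 percentage points higher from compound 2 to compound 4 (beyond the scatter). Set beside the earlier case, the size of the step cannot be told apart on the two cores: the same change on two cores in this assay, a number 6.5 percentage points higher (within the scatter) from compound 3 to compound 1 and a number 10.6 percentage points higher (beyond the scatter) from compound 2 to compound 4, 4.1 percentage points apart, within the scatter of two such steps. Going by these compounds alone, this rests on only two pairs, so it does not show that the step would hold on any other core, nor does it explain why the number moves.

The compounds shown leave open what a chain longer than 2-hydroxyethyl, or an amine or a carboxylic acid in place of the hydroxy group, would do to this number. Also open, as far as these compounds go, is whether the same change would give a similar step on a core carrying other groups.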